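Swapping phenyl for methoxycarbonyl on a shorter chain

The source may report more compounds than this note shows. Statements on the series, on what has been measured and on what is new or still open speak of the compounds shown alone.

Going by these compounds, the set contains three measured triazoles and one that is still open. Compound 1, `CC(C)=CCC/C(C)=C/CC/C(C)=C/Cn1cc(-c2ccccc2)nn1`, carries a phenyl on its core and gives 6.95 in a physicochemical assay for lipophilicity, measured as octanol-water partition; on this read-out lower numbers stand for lower lipophilicity and higher numbers for higher lipophilicity. Compound 2, `COC(=O)c1cn(C/C=C(\C)CC/C=C(\C)CCC=C(C)C)nn1`, keeps the same long chain but bears a methoxycarbonyl on the aromatic carbon instead; in this assay compound 2 gives 5.25. The difference between compound 1 and compound 2 is methoxycarbonyl in place of phenyl on an aromatic carbon and the step it made was a number 1.70 log units lower from compound 1 to compound 2 (beyond the scatter).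

Compound 3, `CC(C)=CCC/C(C)=C\Cn1cc(-c2ccccc2)nn1`, has a shorter chain than compound 1 and keeps the phenyl; in this assay compound 3 gives 4.91, the lowest of the three numbers, and its value lies under that of compound 2 as well. How the core of compound 3 differs from the core of compound 1 is not broken down here.

Compound 4, `COC(=O)c1cn(C/C=C(/C)CCC=C(C)C)nn1`, has not yet been measured. Its difference from compound 3 is methoxycarbonyl in place of phenyl on an aromatic carbon, the same change seen between compound 1 and compound 2, at the same place on the ring. Because that change gave a number 1.70 log units lower from compound 1 to compound 2 (beyond the scatter), a step of similar size is expected here, that is a number 1.71 log units lower from compound 3 to compound 4 (beyond the scatter). On this basis compound 4 is expected to give about 3.2 in this assay, with a likely range from 2.7 to 3.7.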

Compound 4, partition coefficient: 3.2
Beside the measured number, compound 4's estimate shows no gap at the digits printed; the range from low to high includes it.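

In this assay, putting methoxycarbonyl in place of phenyl on the aromatic carbon gave a number 1.71 log units lower from compound 3 to compound 4 (beyond the scatter), while the same change on the core of compound 1 gave a number 1.70 log units lower from compound 1 to compound 2 (beyond the scatter), so the step kept nearly the same size on both cores, and within these two pairs it can be treated as carrying over from one core to the other. For the compounds shown here, this agreement rests on only two pairs that share the same ring and the same point of attachment, so it does not show that the step would keep its size on any other core, at any other place on the ring, or in any other read-out. Nothing measured here accounts for why the two steps came out so close, and the agreement itself offers no explanation.

The compounds shown leave open whether a carboxylic acid, a primary amide or an aminomethyl group on the same aromatic carbon would give a step of similar size on both cores. They also leave open whether the match would survive on a fully saturated chain, or on a chain ending in a hydroxyl group.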